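The source may hold more compounds than are shown below. What is called first, only, known or untested is meant among the compounds shown, and "the series" means these compounds.

Compound 2 `O=C1C=C(Nc2ccccc2)C(=O)c2cnccc21` reaches 93% in a functional assay on the whole organism (aorta) with Rattus norvegicus as the target; a lower number here means a smaller maximal response, a higher number a larger maximal response. Two related compounds have also been measured: compound 1 `O=C1C(Nc2cccc(F)c2)=CC(=O)c2ncccc21` gives 85%, and compound 3 `O=C1C=C(Nc2cccc(F)c2)C(=O)c2cnccc21` gives 89%. Compound 2 therefore holds the largest of the three numbers, yet neither gap to the other two is beyond the usual scatter of this kind of measurement, so the three compounds cannot be told apart with confidence.

Compound 4 `O=C1C=C(Nc2ccc(Cl)cc2)C(=O)c2cnccc21` has not yet been measured. Compared with compound 2, the change is chloro in place of hydrogen on an aromatic carbon.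

Among the measured compounds shown here, only one measured step speaks to this kind of change, a halogen entering in place of hydrogen on the same ring: a number 4 percentage points lower from compound 2 to compound 3 (within the scatter). That step did not leave the scatter. On that basis, no step beyond the scatter is expected for compound 4 in this assay, and the expected change is a number 3 percentage points lower from compound 2 to compound 4 (within the scatter). Compound 4 is estimated to give 90%, within a range from 80% to 98%.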

Compound 4, largest response reached (Emax), in percent of the reference or control that the assay uses: 96%
The estimate for compound 4 lay 6 percentage points below the measured number, within the range that was stated.
By their numbers in this assay, from the lowest: compounds 1, 3, 2 and 4 (each within the scatter of the next, the first and the last beyond it).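

In this assay, placing chloro on the aromatic carbon para to a large group leaves the maximal response within the scatter of compound 2, as a number 3 percentage points higher from compound 2 to compound 4 (within the scatter) shows. Among the compounds shown here, this is the first look at chloro on this ring, and it adds a second halogen step to a number 4 percentage points lower from compound 2 to compound 3 (within the scatter), so neither of the two halogen changes on the ring shifts the response measurably from that of compound 2. No measured information is available to explain this result.

From the compounds shown here alone, what stays open is whether a group other than a halogen, such as an amine, a carboxylic acid or a longer chain, would move the response beyond the scatter at this same position. It is also unclear whether chloro at another carbon of the ring would behave as it does here.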